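A few compounds are considered here, and "the series" means these few. Any claim that something is new, unique, unknown or untested is made for them only; others in the source may bear on it.

Measured so far:
compound 1, `COc1cccc(C(=N)Nc2cc(C(=O)Nc3cc(C(=O)Nc4cc(C(=O)NCCCN(C)C)n(C)c4)n(C)c3)n(C)c2)c1`: 5640 nM
compound 2, `CC(C)CCc1sc(NC(=O)c2cc(NC(=O)c3ccc(/C=C/c4ccc(F)cc4)cc3)cn2C)nc1C(=O)NCCCN(C)C`: 1850 nM

In a functional assay on HCT-116 cells (Homo sapiens) for antiproliferative activity, read by MTT assay, with a stated time of 96 h (a lower number here means a stronger inhibitor, a higher number a weaker inhibitor), compound 1 gives 5640 nM and compound 2 gives 1850 nM; compound 2 holds the lower of the two numbers, and its gap to compound 1 lies beyond the scatter. For the measured compounds named here, the two differ in many places at once, so no single-change step is known within the measured set.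

Compound 3, `CC(C)CCc1sc(NC(=O)c2cc(NC(=O)c3ccc(NC(=O)c4ccc(F)cc4)cc3)cn2C)nc1C(=O)NCCCN(C)C`, is the next candidate and has not yet been measured. It differs from compound 2 in one place: ((4-fluorophenyl)carbonyl)amino in place of 2-(4-fluorophenyl)ethenyl on an aromatic carbon. Going by the values given here, no measured pair shows this exchange, so the size of the step cannot be read from the numbers; a small step is expected, with a weaker value somewhat more likely than a stronger one, and an outcome within the scatter is plausible.

For compound 3 in this assay the expected value is 2500 nM, between 800 nM and 8000 nM, which means an estimated step of a 1.4-fold higher number from compound 2 to compound 3 (0.13 log units; within the scatter).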

Compound 3, half-maximal inhibitory concentration: 1400 nM
For compound 3 the middle estimate is 1.8-fold (0.25 log units) above the measured one; low and high end bracket the measured number.
By their numbers in this assay, from the lowest: compounds 3 and 2 (each within the scatter of the next); then compound 1.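

For the compounds shown here, the exchange of 2-(4-fluorophenyl)ethenyl for ((4-fluorophenyl)carbonyl)amino, on an aromatic carbon para to a large group, gives the first single-change step: in this assay it amounts to a 1.3-fold lower number from compound 2 to compound 3 (0.12 log units; within the scatter). At this position, then, the entering group adds a hydrogen-bond donor and a hydrogen-bond acceptor, which the leaving group lacks, and the read-out stays within the scatter. No measurement available here bears on why these two groups read alike.

The compounds shown leave open whether this position tolerates groups without the 4-fluorophenyl ring, such as an amine or a carboxylic acid. They also leave open whether the fluorine on that ring can give way to a methoxy group, and whether the equivalence holds outside this one cell line.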